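The source may report more compounds than this note shows. Statements on the series, on what has been measured and on what is new or still open speak of the compounds shown alone.

Measured in a functional assay on OVCAR-5 cells (Homo sapiens) for inhibition, read by CCK-8 assay, with a stated time of 72 h, tested at 1 uM; on this read-out higher numbers stand for more inhibition of growth at the one concentration tested and lower numbers for less inhibition of growth:
- compound 1 `CN(C)C(=O)c1cc2cnc(Nc3ccc(NC(=O)C4(C(=O)Nc5cccc(F)c5)CC4)cc3)nc2n1C1CCCC1`: 26.3%
- compound 2 `CN(C)C(=O)c1cc2cnc(Nc3ccc(NC(=O)C4(C(=O)Nc5cccc(Cl)c5)CC4)cc3)nc2n1C1CCCC1`: 15.5%
- compound 3 `CN(C)C(=O)c1cc2cnc(Nc3ccc(NC(=O)C4(C(=O)Nc5ccc(Cl)c(C(F)(F)F)c5)CC4)cc3)nc2n1C1CCCC1`: -2.4%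

Compound 3 stands lowest of the three, beyond the scatter from both others. Compound 4 `CN(C)C(=O)c1cc2cnc(Nc3ccc(NC(=O)C4(C(=O)Nc5ccc(O)cc5)CC4)cc3)nc2n1C1CCCC1` carries 4-hydroxyphenyl in place of 4-chloro-3-(trifluoromethyl)phenyl on an amide-type nitrogen. The leaving group went with lower numbers in two measured steps on that nitrogen: a number 28.7 percentage points lower from compound 1 to compound 3 (beyond the scatter) and a number 17.9 percentage points lower from compound 2 to compound 3 (beyond the scatter). The smaller change shows a number 10.8 percentage points lower from compound 1 to compound 2 (beyond the scatter). Among the compounds with values here, no measured compound carries 4-hydroxyphenyl, so the size remains uncertain. The expected step is upward and of similar size, with a number 24.4 percentage points higher from compound 3 to compound 4 (beyond the scatter) as the estimate. For compound 4 the estimated value is 22% with an expected range of 3% to 48%.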

Compound 4, percent growth inhibition at one concentration: 80.7%
Estimate against measurement, compound 4: 58.7 percentage points below, and the stated range ends below it.
By their numbers in this assay, from the lowest: compound 3; then compound 2; then compound 1; then compound 4.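

In this assay the group on the amide-type nitrogen proves able to move the read-out far more than the modest earlier steps showed: 4-hydroxyphenyl gives a number 83.1 percentage points higher from compound 3 to compound 4 (beyond the scatter) and a number 65.2 percentage points higher from compound 2 to compound 4 (beyond the scatter) and also a number 54.4 percentage points higher from compound 1 to compound 4 (beyond the scatter) in a large step each time. Halogen-bearing rings alone did not reveal this range at the position. Nothing available explains the gain.

Each step exchanges the whole aryl group, so the hydroxyl cannot be separated from the loss of the halogens. From the compounds shown here alone, whether 4-methoxyphenyl, 4-aminophenyl or unsubstituted phenyl would keep the gain remains open.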